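This account rests on a few compounds, and the source may have more. Where it says the series, first, only, none or still open, it means among the compounds named here.

Compound 1 `CC(=O)Oc1ccccc1C(=O)O[C@H]1CO[C@H]2[C@@H]1OC[C@H]2OC(=O)C1CC1` gives 0.015 h in an ADME assay on a cell-free system (plasma, Homo sapiens) for metabolic stability, with Plasma (Rattus norvegicus) as the target, read by HPLC, at pH 7.4; on this read-out higher numbers stand for a longer-lived compound and lower numbers for a shorter-lived compound. Compound 2 `CC(=O)Oc1ccccc1C(=O)O[C@H]1CO[C@H]2[C@@H]1OC[C@H]2OC(=O)c1ccccc1` gives 0.0107 h. Compound 3 `CC(=O)Oc1ccccc1C(=O)O[C@H]1CO[C@H]2[C@@H]1OC[C@H]2OC(=O)c1cccnc1` gives 0.00617 h.

Compound 3 stands at the low end of the three numbers: its gap to compound 2 is within the scatter, while a 2.4-fold lower number from compound 1 to compound 3 (0.39 log units; beyond the scatter). The unmeasured compound 4 `CC(=O)Oc1ccccc1C(=O)O[C@H]1CO[C@H]2[C@@H]1OC[C@H]2OC(=O)c1ccncc1` differs from compound 3 in one place: pyridin-4-yl in place of pyridin-3-yl on a carbonyl carbon. Among the measured compounds shown here, no measured step swaps one pyridyl for another. The nearest comparisons are a 1.7-fold lower number from compound 2 to compound 3 (0.24 log units; within the scatter) and a 1.4-fold lower number from compound 1 to compound 2 (0.15 log units; within the scatter), both within the scatter, and only a 2.4-fold lower number from compound 1 to compound 3 (0.39 log units; beyond the scatter) was modest. This change is therefore expected to give a step of about a 1.0-fold lower number from compound 3 to compound 4 (0.01 log units; within the scatter), not beyond the scatter. Compound 4 is estimated at 0.006 h, within a range from 0.003 h to 0.012 h.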

Compound 4, half-life: 0.0055 h
The estimate for compound 4 lay 1.1-fold (0.04 log units) above the measured number; the measured number falls inside the stated range.
By their numbers in this assay, from the lowest: compounds 4, 3, 2 and 1 (each within the scatter of the next, the first and the last beyond it).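

In this assay, among the compounds shown here, the first swap of one pyridyl for another on this carbonyl carbon gives a 1.1-fold lower number from compound 3 to compound 4 (0.05 log units; within the scatter) and so does not separate pyridin-4-yl from pyridin-3-yl. For the compounds shown here, the step from phenyl is a 1.9-fold lower number from compound 2 to compound 4 (0.29 log units; within the scatter) and the step from cyclopropyl is a 2.7-fold lower number from compound 1 to compound 4 (0.44 log units; beyond the scatter) and so, as with pyridin-3-yl, only the step from cyclopropyl lies beyond the scatter. Nothing available explains these half-lives. Still open, going by these compounds, is how pyridin-2-yl, an amine or a longer alkyl chain on this carbonyl carbon would compare.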